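The source may report more compounds than this note shows. Statements on the series, on what has been measured and on what is new or still open speak of the compounds shown alone.

Compound 3 `O=C(NCCCCCCCn1cc(-c2cccnc2)nn1)c1ccccc1-n1cc(CN2CCC(O)CC2)nn1` gives 41.8 nM in an assay for inhibition of Nicotinamide phosphoribosyltransferase (Mus musculus), read by fluorescence, with a stated time of 1 h, in the presence of a further agent that is not named here (on this read-out lower numbers stand for stronger inhibition and higher numbers for weaker inhibition), the smaller of the two numbers available, though this distinction from its nearest companion lies within the scatter. That companion, compound 2 `O=C(NCCCCCCCn1cc(-c2cccnc2)nn1)c1ccccc1-c1c[nH]nn1`, gives 42.5 nM in this assay. Compound 1 `O=C(O)c1cccc(-c2ccccc2C(=O)NCCCCCCCn2cc(-c3cccnc3)nn2)c1` is reported in this assay only as a limit, > 500 nM, noted as the limit of > 500 nM in this assay, at which 1 of the 3 values shown sits.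

For the measured compounds named here, the single measured step, an at least 11-fold lower number from compound 1 to compound 2 (1.07 log units; beyond the scatter), concerns the group carried on an aromatic carbon of the shared core. Compound 4 `O=C(NCCCCCCCn1cc(-c2cccnc2)nn1)c1ccccc1-n1cc(CN2CCCC2)nn1` differs from compound 3 at a different place: pyrrolidin-1-yl in place of 4-hydroxypiperidin-1-yl on a saturated chain carbon bound to an aromatic carbon. Going by the values given here, none of the measured steps touches this saturated chain carbon or the ring attached to it, so the step from compound 1 to compound 2, large as it was, offers no direct guide to the present change. Compounds 2 and 3 show that the two quite different groups on the aromatic carbon give numbers within the scatter of each other, which suggests this region tolerates variation, but nothing measured speaks to the ring at the far end.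

The estimated step, a 1.2-fold higher number from compound 3 to compound 4 (0.08 log units; within the scatter), is therefore none beyond the scatter. Compound 4 is expected to give about 50 nM in this assay, within a range from 20 nM to 150 nM.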

Compound 4, half-maximal inhibitory concentration: 25.4 nM
For compound 4 the middle estimate is 2.0-fold (0.29 log units) above the measured one; measured number inside the range.
By their numbers in this assay, from the lowest: compounds 4, 3 and 2 (each within the scatter of the next). At a limit, above all of these: compound 1.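

Replacing 4-hydroxypiperidin-1-yl with pyrrolidin-1-yl on a saturated chain carbon bound to an aromatic carbon gives a 1.6-fold lower number from compound 3 to compound 4 (0.22 log units; within the scatter), so in this assay this position accepts a smaller ring without the hydroxy group and with no hydrogen-bond donor, and the number stays within the scatter. The comparison with the unsubstituted triazole gives a 1.7-fold lower number from compound 2 to compound 4 (0.22 log units; within the scatter), so the 4-((pyrrolidin-1-yl)methyl)-1H-1,2,3-triazol-1-yl group cannot be told apart from the 1H-1,2,3-triazol-4-yl group on the aromatic carbon, and the three compounds with a measured number form a single group in this assay. Only an at least 19-fold lower number from compound 1 to compound 4 (1.29 log units; beyond the scatter) lies beyond the scatter, and its starting figure is a limit, not a number: the limit of > 500 nM in this assay, at which 1 of the 4 values shown sits.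

The compounds shown leave open whether an open-chain amine such as dimethylamino, a morpholine ring or a carboxylic acid on the same saturated chain carbon would stay within this group. They also leave open whether a shorter or longer chain in place of the seven-carbon chain of the shared core would keep these numbers in this assay.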